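A few compounds are considered here, and "the series" means these few. Any claim that something is new, unique, unknown or untested is made for them only; others in the source may bear on it.

Compound 3 `Cc1cn2c(-c3cn[nH]c3)cnc2c(Nc2cc(Cc3ncccn3)ns2)n1` was tested in an ADME assay on the whole organism for pharmacokinetics, with Rattus norvegicus as the target, with a stated time of 6 h, at a dose of 10 mg/kg by the oral route (on this read-out lower numbers stand for lower exposure and higher numbers for higher exposure at the dose given), and gave 701 ng.h/mL. Among the compounds shown here it is the only one with a number in this assay: compound 1 `Cc1cn2c(-c3cn[nH]c3)cnc2c(Nc2cc(Cn3cccc3)ns2)n1` has no result reported in this assay "not determined" (no result reported), and compound 2 `Cc1cn2c(-c3cn[nH]c3)cnc2c(Nc2cc(Cn3cccn3)ns2)n1` likewise has no result reported "not determined" (no result reported). Compound 3 therefore stands alone, with no comparison within the set to place it as high or low.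

Compound 4 `Cc1cn2c(-c3cn[nH]c3)cnc2c(Nc2cc(Cc3ccccn3)ns2)n1` has not yet been measured in this assay. It differs from compound 3 by a single change: pyridin-2-yl in place of pyrimidin-2-yl on a saturated chain carbon bound to an aromatic carbon. Going by the values given here, no step between two measured compounds is available to guide this change, and the pair of compounds 1 and 2 contribute no numbers. With only the value of compound 3 701 ng.h/mL as an anchor, the step from compound 3 to compound 4 is expected to be small, in no particular direction and within the usual scatter, a 1.0-fold lower number from compound 3 to compound 4 (0.00 log units; within the scatter). Compound 4 is thus estimated at 700 ng.h/mL, with a range from 250 ng.h/mL to 2000 ng.h/mL.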

Compound 4, area under the concentration-time curve: 6880 ng.h/mL
Compound 4: middle estimate off by 9.8-fold (0.99 log units), on the low side; measured number above the stated range.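

In this assay, exchanging (pyrimidin-2-yl)methyl for (pyridin-2-yl)methyl gives a 9.8-fold higher number from compound 3 to compound 4 (0.99 log units; beyond the scatter), so this place, on a saturated chain carbon bound to an aromatic carbon, is not indifferent to the ring it carries. The two rings have the same count of heavy atoms, and the entering ring differs only in holding one hetero atom and one hydrogen-bond acceptor fewer, yet exposure moves well beyond the usual scatter. Nothing measured here accounts for this rise.

This single pair cannot show whether the rise belongs to the pyridin-2-yl ring alone or would carry over to other rings at this place. From the compounds shown here alone, what a plain phenyl ring, or a pyridin-2-yl ring bearing an amine or a methoxy group, would do in this assay remains open.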